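Swapping chloro for fluoro on an aromatic carbon

The compounds below may be only part of what the source reports. "The series", "measured", "known", "first", "only" and "open" are said of these compounds alone.

Compound 1 `CCn1cc(C(=O)O)c(=O)c2cc(F)c(N3CCN(CN4C(=O)/C(=N\NC(=S)NOC)c5cc(Cl)ccc54)CC3)cc21` gives 193000 nM
Compound 2 `CONC(=S)N/N=C1\C(=O)N(CN2CCN(c3c(F)cc4c(=O)c(C(=O)O)cn(C5CC5)c4c3OC)CC2C)c2ccc(F)cc21` gives 171000 nM

Both numbers come from an ADME assay on MT4 cells (Homo sapiens) for cytotoxicity, read by spectrophotometry, with a stated time of 5 days; a lower number here means that less compound is tolerated, a higher number that more compound is tolerated. Compound 1 and compound 2 lie within the usual scatter of repeated measurements, and neither can be ranked above the other.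

Compound 3 `CCn1cc(C(=O)O)c(=O)c2cc(F)c(N3CCN(CN4C(=O)/C(=N\NC(=S)NOC)c5cc(F)ccc54)CC3)cc21` has not yet been measured. It differs from compound 1 in one place: fluoro in place of chloro on an aromatic carbon. The change sits on a six-membered aromatic ring of carbon only, part of a fused or bridged system of two rings.

Going by the values given here, no measured pair shows this swap directly. The expectation therefore rests on the close values of compound 1 at 193000 nM and compound 2 at 171000 nM. In this assay, no change beyond the scatter is expected, and the estimated change is a 1.1-fold lower number from compound 1 to compound 3 (0.03 log units; within the scatter). For compound 3 the estimated value is 180000 nM, with an expected range from 95000 nM to 320000 nM.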

Compound 3, half-maximal cytotoxic concentration: 144000 nM
Beside the measured number, compound 3's estimate is 1.3-fold (0.10 log units) above it; low and high end bracket the measured number.
By their numbers in this assay, from the lowest: compounds 3, 2 and 1 (each within the scatter of the next).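

Going by these compounds alone, this pair gives the first direct reading of the swap, with everything else in the molecule held the same: in this assay there is a 1.3-fold lower number from compound 1 to compound 3 (0.13 log units; within the scatter) when fluoro takes the place of chloro. At this aromatic carbon, meta to a fused ring and para to a fused ring, the two halogens therefore cannot be told apart by how much compound the cells tolerate. Nothing measured here explains this result.

As far as these compounds go, whether bromo, a methyl group or an amine on this same carbon would also stay within the scatter remains open, as does the effect of having only hydrogen there. It is also unknown whether the swap would read the same way with a different group on the rest of the shared core.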